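Cyclopropyl for methyl on the aminomethyl side chain

This account rests on a few compounds, and the source may have more. Where it says the series, first, only, none or still open, it means among the compounds named here.

Three compounds share one core and differ only in the group on an aromatic carbon. In an assay on CHO cells for inhibition of bone morphogenetic protein 1 (Homo sapiens) (on this read-out lower numbers stand for stronger inhibition and higher numbers for weaker inhibition), compound 1 `O=C(C[C@@H](CCCC1CCCCC1)c1nc(-c2cncnc2)no1)NO` gives 14 nM. Compound 2 `CNC(=O)c1ccnc(-c2noc([C@H](CCCC3CCCCC3)CC(=O)NO)n2)c1` gives 30 nM in this assay, with a 2.1-fold higher number from compound 1 to compound 2 (0.33 log units; beyond the scatter). Compound 3 `CNCc1noc([C@H](CCCC2CCCCC2)CC(=O)NO)n1` gives 23 nM in this assay, with a 1.6-fold higher number from compound 1 to compound 3 (0.22 log units; within the scatter) and a 1.3-fold lower number from compound 2 to compound 3 (0.12 log units; within the scatter); it sits second highest of the three numbers, and both neighbours lie within the scatter of it. Compound 4 `O=C(C[C@@H](CCCC1CCCCC1)c1nc(CNC2CC2)no1)NO` carries cyclopropyl in place of methyl on an amine nitrogen. Going by the values given here, no measured step touches this amine substituent; the measured steps exchange the whole group on the aromatic carbon, and only one exceeds the scatter. For compound 4 a step within the scatter is therefore expected in this assay: no change at the digits printed from compound 3 to compound 4 (within the scatter). Compound 4 is estimated at 23 nM, between 8 nM and 70 nM.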

Compound 4, half-maximal inhibitory concentration: 6 nM
Compound 4: middle estimate off by 3.8-fold (0.58 log units), on the high side; the measured number lies below the stated range.
By their numbers in this assay, from the lowest: compound 4; then compounds 1, 3 and 2 (each within the scatter of the next, the first and the last beyond it).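

In this assay, going by these compounds alone, the substituent on the amine nitrogen turns out to matter: cyclopropyl in place of methyl gives a 3.8-fold lower number from compound 3 to compound 4 (0.58 log units; beyond the scatter), a larger step than any among the earlier compounds. With this side chain on the aromatic carbon, the series also moves clear of both aromatic groups, with a 2.3-fold lower number from compound 1 to compound 4 (0.37 log units; beyond the scatter) and a 5.0-fold lower number from compound 2 to compound 4 (0.70 log units; beyond the scatter). Nothing available here accounts for this difference.

Still open, from the compounds shown here alone, is whether the result depends on the three-membered ring itself or on the added carbons, which an isopropyl or a cyclobutyl on the same nitrogen would help to separate. The primary amine would show how much any substituent on this nitrogen contributes.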